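Swapping the Cyclopropyl Amide of Compound 2 for Chlorobutyl

The source may report more compounds than this note shows. Statements on the series, on what has been measured and on what is new or still open speak of the compounds shown alone.

Compound 2 `COc1ccc(CN(C(=O)C2CC2)c2cc(OC)c(OC)c(OC)c2)cc1O` gives the lowest number of the three measured compounds in a functional assay on HCT-116 cells (Homo sapiens) for inhibition, read by MTT assay, with a stated time of 48 h (on this read-out higher numbers stand for weaker inhibition and lower numbers for stronger inhibition), at 49 nM. Compound 3 `C/C=C/C(=O)N(Cc1ccc(OC)c(Br)c1)c1cc(OC)c(OC)c(OC)c1` gives 2800 nM, and compound 1 `C/C=C/C(=O)N(Cc1cccc(O)c1)c1cc(OC)c(OC)c(OC)c1` gives 6700 nM. For the measured compounds named here, the one step that can be traced within this set, a 2.4-fold lower number from compound 1 to compound 3 (0.38 log units; beyond the scatter), concerns the benzylic ring and not the acyl group, so it does not bear on the change now at hand. Compound 4 `COc1ccc(CN(C(=O)CCCCCl)c2cc(OC)c(OC)c(OC)c2)cc1O` differs from compound 2 only at the carbonyl carbon: 4-chlorobutyl in place of cyclopropyl on a carbonyl carbon. Compounds 1 and 3, both carrying an unsaturated acyl chain rather than cyclopropyl, sit far above compound 2, but each also differs from it on the benzylic ring, so no single comparison isolates the acyl group. Going by the values given here, with no direct precedent, a modest loss is expected, as a flexible 4-chlorobutyl chain replaces the ring. Compound 4 is therefore estimated at 200 nM, within 40 nM to 1500 nM, a step of a 4.1-fold higher number from compound 2 to compound 4 (0.61 log units; beyond the scatter) expected in this assay.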

Compound 4, half-maximal inhibitory concentration: 220 nM
For compound 4 the middle estimate is 1.1-fold (0.04 log units) below the measured one; measured number inside the range.
By their numbers in this assay, from the lowest: compound 2; then compound 4; then compound 3; then compound 1.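

For the compounds shown here, compound 4 gives the first direct reading of the acyl position, since only the group on the carbonyl carbon changes: in this assay, 4-chlorobutyl in place of cyclopropyl gives a 4.5-fold higher number from compound 2 to compound 4 (0.65 log units; beyond the scatter) and so marks a modest step, beyond the scatter. The three-membered ring is therefore not required for a number of this order in this series, though the open chain does not match it. No measurement is available that would account for the size of this step.

On these data alone, it remains open whether the loss follows from opening the ring, from the longer chain or from the chlorine; a butyl chain without chlorine, a cyclobutyl ring or a 4-aminobutyl chain would separate these. As far as these compounds go, whether the step keeps its size with the other benzylic rings of compound 1 and compound 3 also stays unknown.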